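Aryl swap on the ring nitrogen: compound 3 to compound 4

The source may report more compounds than this note shows. Statements on the series, on what has been measured and on what is new or still open speak of the compounds shown alone.

Measured so far in an assay on HEK293 cells for inhibition of Voltage-dependent T-type calcium channel subunit alpha-1G (Homo sapiens), read by patch clamp; a lower number here means a stronger inhibitor, a higher number a weaker inhibitor:
compound 1 `CCCc1nc(-c2ccccc2)c(CNCCCN2CCN(c3ccc(F)cc3)CC2)o1`: 3210 nM
compound 2 `CCCc1nc(-c2ccccc2)c(CNCCCN2CCN(c3cccc(C(F)(F)F)c3)CC2)o1`: 650 nM
compound 3 `CCCc1nc(-c2ccccc2)c(CNCCCN2CCN(c3ccc(C(F)(F)F)cc3)CC2)o1`: 7250 nM

Compound 3 gives the highest number of the three; its nearest neighbour is compound 1, reached by a 2.3-fold higher number from compound 1 to compound 3 (0.35 log units; beyond the scatter), and its furthest is compound 2, reached by an 11-fold higher number from compound 2 to compound 3 (1.05 log units; beyond the scatter). Compound 4 `CCCc1nc(-c2ccccc2)c(CNCCCN2CCN(c3ccccc3C)CC2)o1` differs from compound 3 only at the aryl group on the amine nitrogen in the ring: 2-methylphenyl in place of 4-(trifluoromethyl)phenyl on an amine nitrogen in a ring.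

Among the compounds with values here, no measured pair carries a 2-methylphenyl, so the step rests on indirect evidence. Moving the trifluoromethyl around the ring gave the large 11-fold higher number from compound 2 to compound 3 (1.05 log units; beyond the scatter), and swapping fluoro for trifluoromethyl at the same place gave the modest 2.3-fold higher number from compound 1 to compound 3 (0.35 log units; beyond the scatter), so the aryl substituent pattern clearly matters in this assay and compound 3 sits at the weak end. Removing the 4-(trifluoromethyl) and placing a smaller methyl elsewhere on the ring is therefore expected to lower the number, by a modest step of a 4.0-fold lower number from compound 3 to compound 4 (0.61 log units; beyond the scatter), with wide uncertainty. For compound 4 the estimate is 1800 nM, within 450 nM to 7000 nM.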

Compound 4, half-maximal inhibitory concentration: 8750 nM
Beside the measured number, compound 4's estimate is 4.9-fold (0.69 log units) below it, outside the stated range (above it).
By their numbers in this assay, from the lowest: compound 2; then compound 1; then compounds 3 and 4 (each within the scatter of the next).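

In this assay, 2-methylphenyl and 4-(trifluoromethyl)phenyl on the amine nitrogen in the ring cannot be told apart, with a 1.2-fold higher number from compound 3 to compound 4 (0.08 log units; within the scatter), so removing the fluorine atoms from the aryl group does not by itself lower the number. The 3-(trifluoromethyl)phenyl stays well ahead of the new group, with a 13-fold higher number from compound 2 to compound 4 (1.13 log units; beyond the scatter), and the 4-fluorophenyl keeps a smaller advantage, with a 2.7-fold higher number from compound 1 to compound 4 (0.44 log units; beyond the scatter). The low number of compound 2 therefore remains confined to that one aryl group, and the 2-methylphenyl offers no second route to it.

No evidence is available on why these aryl groups fall in this order. Both the substituent and its place on the aryl ring change in this step, so their contributions remain unseparated, and an unsubstituted phenyl, a methoxy or a nitrile on that ring could help to separate them.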